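From compound 1 to compound 4: one trifluoromethyl swap

A few compounds are considered here, and "the series" means these few. Any claim that something is new, unique, unknown or untested is made for them only; others in the source may bear on it.

In an in vitro ADME assay on microsomes from liver (Homo sapiens) for metabolic stability (a lower number here means slower removal, a higher number faster removal of the compound), compound 1 (`COCCc1nc2nc(C)cc(Nc3ccc(S(F)(F)(F)(F)F)cc3)n2n1`) stands at 11.5 mL.min-1.g-1 and holds the higher of the two actual numbers. Its nearest neighbour, compound 3 (`COCc1nc2nc(C)cc(Nc3ccc(S(F)(F)(F)(F)F)cc3)n2n1`), stands at 5.6 mL.min-1.g-1 on the lower side. Compound 2 (`Cc1cc(Nc2ccc(S(F)(F)(F)(F)F)cc2)n2nc(C(F)(F)F)nc2n1`) gives < 5 mL.min-1.g-1 as a limit of the assay and not a number.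

Compound 4 (`COCCc1nc2nc(C)cc(Nc3ccc(C(F)(F)F)cc3)n2n1`) keeps the 2-methoxyethyl chain of compound 1 and differs from it in one place (a group of 4 heavy atoms (1 carbon, 3 fluorine; no ring) in place of a group of 6 heavy atoms (5 fluorine, 1 sulfur; no ring), on an aromatic carbon). Trifluoromethyl enters on an aromatic carbon of a six-membered aromatic ring of carbon only, para to a large group. Among the compounds with values here, no measured step touches that place. The two steps leaving compound 1 both change the 2-methoxyethyl chain instead. One is an at least 2.3-fold lower number from compound 1 to compound 2 (0.36 log units; beyond the scatter) and puts trifluoromethyl on the other side of the molecule. The other is a 2.1-fold lower number from compound 1 to compound 3 (0.31 log units; beyond the scatter) and shortens the chain to methoxymethyl. Both are modest in size and bear on the new change only indirectly, so no direction can be drawn from them.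

In this assay the expected change is therefore none beyond the scatter, and the estimated step is a 1.2-fold lower number from compound 1 to compound 4 (0.06 log units; within the scatter) on that reading. Compound 4 is expected at 10 mL.min-1.g-1 with 5.5 mL.min-1.g-1 to 19 mL.min-1.g-1 as the estimated range.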

Compound 4, intrinsic clearance in microsomes: 9 mL.min-1.g-1
For compound 4 the middle estimate is 1.1-fold (0.05 log units) above the measured one, and the stated range covers the measured number.
By their numbers in this assay, from the lowest: compounds 3, 4 and 1 (each within the scatter of the next, the first and the last beyond it). At a limit, below all of these: compound 2.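

In this assay the exchange of the group of 6 heavy atoms (5 fluorine, 1 sulfur; no ring) for trifluoromethyl, on an aromatic carbon of a six-membered aromatic ring of carbon only, para to a large group, gives a 1.3-fold lower number from compound 1 to compound 4 (0.11 log units; within the scatter) and is the only step shown at this place. The earlier steps shown here all changed the other side of the molecule, and the two leaving compound 1 lay beyond the scatter, so compound 4 adds the finding that this exchange on the ring gives no change that can be told from the scatter. No measured information given here bears on why these two groups read so alike.

What the compounds shown leave open is whether another group at this place, such as a nitrile, a chlorine atom or a methoxy group, would also stay within the scatter of compound 1. Also open, from the compounds shown here alone, is whether shortening the 2-methoxyethyl chain to methoxymethyl would give the same step with trifluoromethyl on the ring as it does in compound 1.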